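The source may report more compounds than this note shows. Statements on the series, on what has been measured and on what is new or still open speak of the compounds shown alone.

Measured so far in a functional assay on MOLT-4 cells (Homo sapiens) for antiproliferative activity, read by MTT assay, with a stated time of 72 h; a higher number here means a weaker inhibitor, a lower number a stronger inhibitor:
compound 1 `O=C1NC(=O)/C(=C/C2=Cc3ccccc3OC2)S1` gives 101000 nM
compound 2 `O=C1NC(=S)S/C1=C\C1=Cc2ccccc2OC1` gives 52000 nM
compound 3 `CN1C(=O)S/C(=C\C2=Cc3ccccc3OC2)C1=O` gives only a limit of the assay, > 100000 nM

Compound 2 has the lower of the two numbers, but compound 1 sits within the scatter of it, so no order between them can be read. Compound 4 `O=C(O)CN1C(=O)/C(=C/C2=Cc3ccccc3OC2)SC1=S` differs from compound 2 by carboxymethyl in place of hydrogen on an amide-type nitrogen in a ring. Within the data shown here, the one measured step on the same nitrogen, a step that the limit leaves unreadable from compound 1 to compound 3, cannot be sized because of the limit of > 100000 nM in this assay, at which 1 of the 3 values shown sits. As far as these compounds go, no readable step therefore bears on this change, and both its size and direction stay open. Compound 4 is expected to remain a weak inhibitor in this assay, estimated at 70000 nM with a range of 20000 nM to 200000 nM. For compound 4 the expected step is a 1.3-fold higher number from compound 2 to compound 4 (0.13 log units; within the scatter).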

Compound 4, half-maximal inhibitory concentration: > 100000 nM
Compound 4: a limit, no number (the forecaster's own chance of this, stated with the estimate: 35%); at least 1.4-fold (0.15 log units) between middle value and limit.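

Among these compounds, on the amide-type nitrogen in a ring, this assay now gives a first step for a group larger than methyl: an at least 1.9-fold higher number from compound 2 to compound 4 (0.28 log units; that floor lies within the scatter). As far as these compounds go, compound 4 gives only a limit of the assay, so the true size of this step stays unknown, and its floor alone does not separate the two compounds. Compound 3 and compound 4, each substituted on this nitrogen, both end at a limit, so no readable number yet exists for any group there: the limit of > 100000 nM in this assay, at which 2 of the 4 values shown sit.

From the compounds shown here alone, whether a longer chain ending in an amine on this nitrogen would give a readable number stays open.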